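The source may report more compounds than this note shows. Statements on the series, on what has been measured and on what is new or still open speak of the compounds shown alone.

Measured in a functional assay on MCF7 cells (Homo sapiens) for cytotoxicity, read by MTT assay, with a stated time of 72 h; a higher number here means a weaker inhibitor, a lower number a stronger inhibitor:
- compound 1 `O=C1C(=Cc2cccc(Cl)c2)C(=O)N(c2ccc(Cl)cc2)N1c1ccc(Cl)cc1`: 18300 nM
- compound 2 `COc1ccc(C=C2C(=O)N(c3ccc(Cl)cc3)N(c3ccc(Cl)cc3)C2=O)cc1OC`: > 128000 nM, a limit of the assay
- compound 3 `COc1ccccc1C=C1C(=O)N(c2ccc(Cl)cc2)N(c2ccc(Cl)cc2)C1=O`: 26300 nM

Compound 2 gives only a limit and not a number. Compound 3 therefore has just one numerical neighbour, and the comparison is a 1.4-fold higher number from compound 1 to compound 3 (0.16 log units; within the scatter).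

The next compound is compound 4 `O=C1C(=Cc2ccc(F)cc2F)C(=O)N(c2ccc(Cl)cc2)N1c1ccc(Cl)cc1`, which carries 2,4-difluorophenyl in place of 2-methoxyphenyl on a double-bonded chain carbon bound to a double-bonded ring carbon. Among the measured compounds shown here, no measured step makes this exact exchange, but all three measured steps change the same place. Two steps beyond the scatter, an at least 6.9-fold higher number from compound 1 to compound 2 (0.84 log units; beyond the scatter) and an at least 4.8-fold lower number from compound 2 to compound 3 (0.68 log units; beyond the scatter), both turn on the 3,4-dimethoxyphenyl group, which compound 4 does not carry. The closer guide is the exchange of 3-chlorophenyl for 2-methoxyphenyl, which stayed within the scatter in this assay. On that slim evidence, no step beyond the scatter is expected, and the estimated step is a 1.2-fold lower number from compound 3 to compound 4 (0.08 log units; within the scatter). For the measured compounds named here, only three compounds support this, so the expected range stays wide. Compound 4 is estimated at 22000 nM, with an expected range from 8000 nM to 70000 nM.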

Compound 4, half-maximal inhibitory concentration: 22000 nM
Compound 4: the middle estimate sits on the measured number at the digits printed; measured number inside the range.
By their numbers in this assay, from the lowest: compounds 1, 4 and 3 (each within the scatter of the next). At a limit, above all of these: compound 2.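

In this assay, the oxygen of the 2-methoxyphenyl group leaves and the fluorines of 2,4-difluorophenyl enter on a double-bonded chain carbon bound to a double-bonded ring carbon, giving a 1.2-fold lower number from compound 3 to compound 4 (0.08 log units; within the scatter), while the exchange of 3-chlorophenyl for the same group gives a 1.2-fold higher number from compound 1 to compound 4 (0.08 log units; within the scatter). Against the 3,4-dimethoxyphenyl group, 2,4-difluorophenyl gives an at least 5.8-fold lower number from compound 2 to compound 4 (0.76 log units; beyond the scatter), so among the four compounds shown, compound 2 alone stands apart from three whose numbers lie within the scatter of one another, and three different groups at this place now share that range. Compound 2 still gives a limit of the assay and not a number: the limit of > 128000 nM in this assay, at which 1 of the 4 values shown sits.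

From the compounds shown here alone, what an aryl group carrying an amine or a carboxylic acid would do at this place remains open, as does whether any group here can move the number beyond the scatter towards a stronger inhibitor. The rest of the core is the same in all four compounds, so these compounds say nothing about changes made anywhere else on it.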